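Heteroaryl swaps para to the ethylene linker

The compounds below may be only part of what the source reports. "The series", "measured", "known", "first", "only" and "open" are said of these compounds alone.

Compound 1 `CCC(C)(C)Cc1c[nH]c(CCc2ccc(-c3cnccn3)cc2)n1` gives 107 nM in a functional assay on HEK293 cells for agonist activity at Bombesin receptor subtype-3 (Mus musculus), read by luminescence and calcium flux, with a stated time of 10 min; a lower number here means that less compound is needed, a higher number that more compound is needed for the effect. Compound 2 `CCC(C)(C)Cc1c[nH]c(CCc2ccc(-c3cccc(C#N)n3)cc2)n1` gives 115 nM in this assay, the higher of the two numbers shown, though a 1.1-fold higher number from compound 1 to compound 2 (0.03 log units; within the scatter). Compound 3 `CCC(C)(C)Cc1c[nH]c(CCc2ccc(-c3cnsc3)cc2)n1` carries 1,2-thiazol-4-yl in place of 6-cyanopyridin-2-yl on an aromatic carbon. Going by the values given here, the only step that bears on this change is the heteroaryl swap a 1.1-fold higher number from compound 1 to compound 2 (0.03 log units; within the scatter), which stayed within the scatter, so no step beyond the scatter is expected in this assay for compound 3, and no change at the digits printed from compound 2 to compound 3 (within the scatter) is the estimated step. Compound 3 is expected at about 115 nM, within a range of 40 nM to 330 nM.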

Compound 3, half-maximal effective concentration: 119 nM
Beside the measured number, compound 3's estimate is 1.0-fold (0.01 log units) below it, within the range that was stated.
By their numbers in this assay, from the lowest: compounds 1, 2 and 3 (each within the scatter of the next).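

At this place, on an aromatic carbon para to a large group, the five-membered 1,2-thiazol-4-yl ring now stands in for a six-membered aromatic ring, and this assay records a 1.0-fold higher number from compound 2 to compound 3 (0.01 log units; within the scatter) and a 1.1-fold higher number from compound 1 to compound 3 (0.05 log units; within the scatter). Across these three compounds, neither ring size nor the presence of the nitrile separates the numbers. No measurement here explains this tolerance.

Still open, going by these compounds, is whether an amine or a carboxylic acid at this place, instead of an aromatic ring, would leave the number unchanged.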